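Isoindolinone Platelet Inhibitors: Shifting the Carboxyalkyl Chain

The source may hold more compounds than are shown below. What is called first, only, known or untested is meant among the compounds shown, and "the series" means these compounds.

Compound 1 `CC(CC(=O)O)N1Cc2ccc(NC(=O)CCCC3CCNCC3)cc2C1=O` gives 5400 nM in a functional assay on a cell-free system (Platelet, plasma, Homo sapiens) for inhibition; on this read-out higher numbers stand for weaker inhibition and lower numbers for stronger inhibition. Compound 2 `O=C(O)CCCN1Cc2ccc(NC(=O)CCCC3CCNCC3)cc2C1=O` gives 51000 nM. Compound 3 `O=C(O)CCCN1Cc2ccc(NC(=O)c3ccc(C4CCNCC4)cc3)cc2C1=O` gives 410000 nM.

Among these three, compound 3 stands highest in this assay ; compound 2 is nearest to it and compound 1 furthest. The difference between the core of compound 2 and the core of compound 3 is not broken down here. Compounds 2 and 1 differ in one place, described as 1-(carboxymethyl)ethyl in place of 3-carboxypropyl on an amide-type nitrogen in a ring, and that change gave a 9.4-fold lower number from compound 2 to compound 1 (0.98 log units; beyond the scatter).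

Compound 4 `CC(CC(=O)O)N1Cc2ccc(NC(=O)c3ccc(C4CCNCC4)cc3)cc2C1=O` is not yet measured in this assay . Among the compounds with values here, it differs from compound 3 by 1-(carboxymethyl)ethyl in place of 3-carboxypropyl on an amide-type nitrogen in a ring, the same change as the one made from compound 2 to compound 1. Because a 9.4-fold lower number from compound 2 to compound 1 (0.98 log units; beyond the scatter) was modest but beyond the scatter, a step of similar size and direction is expected here, resting on that single precedent alone. Compound 4 is therefore expected to reach about 50000 nM in this assay , estimated within 15000 nM to 150000 nM, meaning an expected step of an 8.2-fold lower number from compound 3 to compound 4 (0.91 log units; beyond the scatter).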

Compound 4, half-maximal inhibitory concentration: 6200 nM
Compound 4: the middle estimate sits 8.1-fold (0.91 log units) above what was measured, and the stated range ends above it.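

In this assay, the change to 1-(carboxymethyl)ethyl in place of 3-carboxypropyl on the amide-type nitrogen in a ring gave a 66-fold lower number from compound 3 to compound 4 (1.82 log units; beyond the scatter), so it carried to the second core in direction but not in size, as the two steps set side by side show: the same change on two cores in this assay, a 9.4-fold lower number (0.98 log units; beyond the scatter) from compound 2 to compound 1 and a 66-fold lower number (1.82 log units; beyond the scatter) from compound 3 to compound 4, 7.0-fold (0.85 log units) apart, beyond the scatter of two such steps. Within these four compounds the change lowered the number on both cores, and neither pair goes against that direction, but the step measured on one core did not give its size on the other. Within the data shown here, with only two pairs, this does not show how large the step would be on any further core, nor which difference between the two cores goes with the gap in size.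

The compounds shown leave open how a shorter chain, such as carboxymethyl, would behave on the same nitrogen of either core. They also leave open whether an ester in place of the carboxylic acid would keep the gain seen with 1-(carboxymethyl)ethyl.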